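A few compounds are considered here, and "the series" means these few. Any claim that something is new, unique, unknown or untested is made for them only; others in the source may bear on it.

Compound 2 `COc1cccc2c1CCC2c1ncc[nH]1` stands at the edge of what a functional assay on CHO cells for agonist activity at Alpha-1D adrenergic receptor (Homo sapiens), read by FLIPR and calcium flux (on this read-out higher numbers stand for an effect only at larger amounts of compound and lower numbers for an effect already at smaller amounts), can report: in this assay compound 2 gives > 10000 nM, a limit of the assay rather than a number. Compound 1 `COc1c(C)ccc2c1CCC2c1ncc[nH]1` likewise gives > 10000 nM in this assay, again a limit. For the measured compounds named here, the one measured step, a step that the two limits leave unreadable from compound 1 to compound 2, is therefore not readable. Compound 3 `CNC(=O)c1cccc2c1CCC2c1ncc[nH]1` carries methylcarbamoyl in place of methoxy on an aromatic carbon. Going by the values given here, no measured step concerns this kind of change; the only guide is the limit of > 10000 nM in this assay, at which 2 of the 2 values shown sit. One expects the step of an at least 1.1-fold lower number from compound 2 to compound 3 (0.04 log units; that floor lies within the scatter) to stay small, most likely leaving compound 3 at a limit as well. Compound 3 is thus estimated at 9000 nM, between 1500 nM and 40000 nM.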

Compound 3, half-maximal effective concentration: > 10000 nM
Compound 3 ended at the assay's limit (the forecaster's own chance of this, stated with the estimate: 70%); middle value at least 1.1-fold (0.04 log units) from the limit.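

For the compounds shown here, compound 2 and compound 3 both rest at the limit of this assay, so no step between them can be read. The compounds shown leave open what amount of any of them would give an effect: the limit of > 10000 nM in this assay, at which 3 of the 3 values shown sit.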